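Swapping the Aryl Group on a Shared Core

This account rests on a few compounds, and the source may have more. Where it says the series, first, only, none or still open, it means among the compounds named here.

Compound 1, `COc1ccc(-n2cc(Cn3c(=O)oc4ccccc43)nn2)cc1`, gives "active" (no number reported) in a functional assay on the whole organism (strain albino Wistar) for inhibition, with Rattus norvegicus as the target, read by paw edema, with stated times of 1 h and 5 h, at a dose of 0.05 mmol/kg by the oral route; on this read-out lower numbers stand for less inhibition and higher numbers for more inhibition at the one dose given (going by the name of the read-out).
Compound 2, `Cc1ccc2c(c1)oc(=O)n2Cc1cn(-c2ccc(F)cc2)nn1`, gives 80.6% in this assay.
Compound 3, `CCOc1ccc(-n2cc(Cn3c(=O)oc4ccccc43)nn2)cc1`, gives "active" (no number reported) in this assay.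

Compound 1 stands without a single number in this assay: it is reported only as active, and compound 3 is the one further entry in the same position, also without a number. The only numerical anchor in the set is compound 2, which in this assay gives 80.6%. Compound 4, `O=c1oc2ccccc2n1Cc1cn(-c2cccnc2)nn1`, has not yet been measured. It differs from compound 1 by pyridin-3-yl in place of 4-methoxyphenyl on an aromatic nitrogen.

Within the data shown here, no step between two measured compounds is available, so the size of the change from compound 1 to compound 4 in this assay cannot be read from the data. Given that compound 1 is reported as active but without a number, the expected step is a modest one, either downward or none beyond the scatter, rather than a large gain. Taking the value of compound 2 as the only reference point, compound 4 is expected to give roughly 65% in this assay, within a range from 40% to 85%.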

Compound 4, a percentage reported as inhibition, in the whole organism at one dose (the size of the read-out at that dose, not a potency): "active" (no number reported)
The entry for compound 4 holds no number; no gap can be computed for the estimate.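

In this assay, among these compounds, compound 4 gives "active" (no number reported) and compound 1 gives "active" (no number reported), so no step between compound 1 and compound 4 can be read. No measured evidence bears on this result. The compounds shown leave open how pyridin-3-yl in place of 4-methoxyphenyl changes the size of the inhibition.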